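The compounds below may be only part of what the source reports. "The series", "measured", "known", "first", "only" and "open" are said of these compounds alone.

Measured in a physicochemical assay for lipophilicity; a higher number here means a more lipophilic compound, a lower number a more polar compound:
- compound 1 `CCOC(=O)c1ccc(S(N)(=O)=O)cc1`: 1.17
- compound 2 `CNC(=O)c1ccc(S(N)(=O)=O)cc1`: -0.31
- compound 3 `CCCNC(=O)c1ccc(S(N)(=O)=O)cc1`: 0.51

In this assay, compound 3 stands second highest of the three, under compound 1 and over compound 2. Compound 4 `CCCCCCNC(=O)c1ccc(S(N)(=O)=O)cc1` differs from it by propyl in place of hydrogen on a saturated chain carbon, three bonds along the chain from an amide-type nitrogen. The closest measured precedent is ethyl in place of hydrogen, a number 0.82 log units higher from compound 2 to compound 3 (beyond the scatter). The swaps of ethoxy, such as a number 1.48 log units lower from compound 1 to compound 2 (beyond the scatter) and a number 0.66 log units lower from compound 1 to compound 3 (beyond the scatter), replace a different group and bear on this change far less. Propyl is the larger addition, so a somewhat larger rise seems likely. The expected step is a number 1.29 log units higher from compound 3 to compound 4 (beyond the scatter). Compound 4 is estimated at 1.8, with an expected range of 1.4 to 2.3.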

Compound 4, partition coefficient: 2.05
Compound 4: middle estimate off by 0.25 log units, on the low side, within the range that was stated.
By their numbers in this assay, from the lowest: compound 2; then compound 3; then compound 1; then compound 4.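

In this assay, the number keeps climbing as the chain on the amide-type nitrogen grows beyond propyl, with a number 1.54 log units higher from compound 3 to compound 4 (beyond the scatter) for the added propyl and a number 2.36 log units higher from compound 2 to compound 4 (beyond the scatter) for the added pentyl, both large steps. The printed values also place compound 4, with its hexyl chain, over compound 1, which carries ethoxy, so a long enough chain on the amide takes the number past that of the ester. Nothing available here explains the size of these rises. As far as these compounds go, whether the climb goes on with a longer chain such as octyl remains open, as does what an amine or a carboxylic acid at the end of the hexyl chain would do to the number.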